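The source may hold more compounds than are shown below. What is called first, only, known or untested is meant among the compounds shown, and "the series" means these compounds.

Measured so far in a functional assay on DU-145 cells (Homo sapiens) for cytotoxicity, read by MTT assay, with a stated time of 48 h; a higher number here means a weaker inhibitor, a lower number a stronger inhibitor:

- compound 1 `COc1ccc(/C=C/c2cc(OC)c(OC)c(OC)c2-c2ccc(OC)cc2)cc1` gives 34000 nM
- compound 2 `COc1ccc(/C=C/c2cc(OC)c(OC)c(OC)c2-c2ccc(F)c(F)c2)cc1` gives 7500 nM

Of these two, compound 2 has the lower number and is the stronger inhibitor in this assay. The next compound is compound 3 `COc1ccc(/C=C/c2cc(OC)c(OC)c(OC)c2-c2ccc(Cl)cc2)cc1`, which has not yet been measured. It keeps the shared core, but 4-chlorophenyl stands in place of 3,4-difluorophenyl on an aromatic carbon 4-chlorophenyl in place of 3,4-difluorophenyl on an aromatic carbon and nothing else changes.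

Going by the values given here, only one measured step bears on this swap. It is a 4.5-fold lower number from compound 1 to compound 2 (0.66 log units; beyond the scatter), a modest step that put 3,4-difluorophenyl in place of 4-methoxyphenyl at the same carbon. Like 3,4-difluorophenyl, 4-chlorophenyl carries no methoxy group, so compound 3 is expected to stay closer to compound 2 than to compound 1. Among the compounds with values here, no measurement yet compares chlorine with fluorine here, so only a small move toward a higher number is expected. The expected change is a 1.5-fold higher number from compound 2 to compound 3 (0.17 log units; within the scatter), which is an estimate and not a result. For compound 3 the estimated value is 11000 nM, with an expected range from 3500 nM to 30000 nM.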

Compound 3, half-maximal inhibitory concentration: 35000 nM
Compound 3: the middle estimate sits 3.2-fold (0.50 log units) below what was measured; the whole stated range lies below it.
By their numbers in this assay, from the lowest: compound 2; then compounds 1 and 3 (each within the scatter of the next).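

In this assay, the replacement of methoxy by chloro on this phenyl ring gives a 1.0-fold higher number from compound 1 to compound 3 (0.01 log units; within the scatter) and so leaves the number unchanged within the scatter; the earlier step therefore cannot be read as a gain from losing the methoxy group alone. The swap of 3,4-difluorophenyl for 4-chlorophenyl gives a 4.7-fold higher number from compound 2 to compound 3 (0.67 log units; beyond the scatter) and shows that this aromatic carbon, which carries the ring ortho to a 2-(4-methoxyphenyl)ethenyl group, distinguishes between two rings that both carry halogen and no methoxy group. Among these three compounds, only the 3,4-difluorophenyl ring of compound 2 stands apart, and nothing available here explains this difference.

This swap changes both the halogen and the number of halogen atoms on the ring, so the compounds shown cannot say which of the two matters. A 4-fluorophenyl or a 3,4-dichlorophenyl group would separate those two changes, while a ring bearing an amine or a carboxylic acid would test whether this position accepts a very different kind of group.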